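Swapping Indolyl for Fluoromethoxyphenyl in a Cytotoxicity Series

The source may report more compounds than this note shows. Statements on the series, on what has been measured and on what is new or still open speak of the compounds shown alone.

Compound 3 `CC(C)N(Cc1cccc(OCCCCCC(=O)O)c1)C(=O)c1ccc(-c2ccc3[nH]ccc3c2)cc1` is known in an ADME assay on BJ cells (Homo sapiens) for cytotoxicity, read by CellTiter-Glo and resazurin assay, with a stated time of 72 h (on this read-out higher numbers stand for an effect only at larger amounts of compound and lower numbers for an effect already at smaller amounts), only as a limit, at which compound 3 gives > 26000 nM. Compound 1 `CC(C)N(Cc1cccc(OCCCCCC(=O)O)c1)C(=O)c1ccc(-c2cccc3ccccc23)cc1` gives < 1.3 nM, itself a limit. Compound 2 `CC(C)Oc1cccc(-c2ccc(C(=O)N(Cc3cccc(OCCCCCC(=O)O)c3)C(C)C)cc2)c1` also reaches a limit, at > 26000 nM. Starting from compound 1, an at least 20000-fold higher number from compound 1 to compound 2 (4.30 log units; beyond the scatter) and an at least 20000-fold higher number from compound 1 to compound 3 (4.30 log units; beyond the scatter); between the other two, a step that the two limits leave unreadable from compound 2 to compound 3. The change now considered is 2-fluoro-5-methoxyphenyl in place of 1H-indol-5-yl on an aromatic carbon, giving compound 4 `COc1ccc(F)c(-c2ccc(C(=O)N(Cc3cccc(OCCCCCC(=O)O)c3)C(C)C)cc2)c1`. Both earlier replacements of naphthalen-1-yl land at the limit of > 26000 nM in this assay, at which 2 of the 3 values shown sit, and the new aryl group is closer to that of compound 2 than to naphthalen-1-yl, so compound 4 is expected to show a step that the limit leaves unreadable from compound 3 to compound 4 in this assay, with the estimate for compound 4 at 30000 nM (range 6000 nM to 120000 nM), most likely again reported only as a limit.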

Compound 4, half-maximal effective concentration: > 26000 nM
Compound 4 was reported as a limit; the forecaster's own chance of this, stated with the estimate: 75%; the middle value is on the limit's open side.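

With 2-fluoro-5-methoxyphenyl, which has no hydrogen-bond donor, the position gives the same limit in this assay as the 1H-indol-5-yl of compound 3, so that donor does not separate the two results. The separation from naphthalen-1-yl holds for this third replacement, with an at least 20000-fold higher number from compound 1 to compound 4 (4.30 log units; beyond the scatter). The steps from compound 2 and compound 3 to compound 4 cannot be read, and all three values stand as a limit: the limit of > 26000 nM in this assay, at which 3 of the 4 values shown sit.

Left open is how these three compounds differ beyond that limit. Also open, on these data alone, is whether naphthalen-2-yl or a quinoline ring at this position would read like compound 1 or like compound 4.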